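A Trifluoromethyl Step from Compound 2 to Compound 4

A few compounds are considered here, and "the series" means these few. Any claim that something is new, unique, unknown or untested is made for them only; others in the source may bear on it.

Of the compounds shown here, three have been measured in a functional assay on MCF7 cells (Homo sapiens) for cytotoxicity, read by CCK-8 assay, with a stated time of 24 h; a higher number here means a weaker inhibitor, a lower number a stronger inhibitor. Compound 1 `C/C(=C\c1cc(-c2ccc(C)cc2)co1)C(N)=O` gives 1630 nM, compound 2 `C/C(=C\c1cc(-c2ccccc2)cs1)C(N)=O` gives 2680 nM, and compound 3 `C/C(=C\c1cc(-c2ccccc2C)cs1)C(N)=O` gives 4920 nM. Compound 2 holds the second highest of the three numbers; its nearest neighbour is compound 1, and its furthest is compound 3, both within the scatter of it.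

Compound 4 `C/C(=C\c1cc(-c2ccc(C(F)(F)F)cc2)cs1)C(N)=O` has not yet been measured. It differs from compound 2 by trifluoromethyl in place of hydrogen on an aromatic carbon. Going by the values given here, the only measured step that bears on this change is the one from compound 2 to compound 3, which also adds a substituent to an aromatic carbon of the six-membered ring and gives a 1.8-fold higher number from compound 2 to compound 3 (0.26 log units; within the scatter). Among the compounds with values here, that step lies within the scatter, and no measured step tells how a trifluoromethyl at this place behaves, so compound 4 is expected to give a number close to that of compound 2, with a step of a 1.3-fold higher number from compound 2 to compound 4 (0.12 log units; within the scatter) in this assay, not beyond the scatter. Compound 4 is therefore estimated at 3500 nM, within a range from 1500 nM to 9000 nM.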

Compound 4, half-maximal inhibitory concentration: 50000 nM
Beside the measured number, compound 4's estimate is 14-fold (1.15 log units) below it; measured number outside the range, above it.
By their numbers in this assay, from the lowest: compounds 1, 2 and 3 (each within the scatter of the next, the first and the last beyond it); then compound 4.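

In this assay, trifluoromethyl in place of hydrogen on an aromatic carbon, para to a large group, gives a 19-fold higher number from compound 2 to compound 4 (1.27 log units; beyond the scatter) and is large. Going by these compounds alone, this shows that the number is sensitive to what stands at this carbon of the six-membered aromatic ring, which the earlier compounds gave no sign of: their only single-change step, the methyl step of a 1.8-fold higher number from compound 2 to compound 3 (0.26 log units; within the scatter), stayed within the scatter, so a substituent on this ring had not yet been seen to matter. No measurement shown here accounts for the size of the trifluoromethyl step, and nothing available speaks to its cause.

The compounds shown leave open whether this large step belongs to trifluoromethyl alone or would also appear with other groups at the same carbon, such as a single fluorine, a methoxy group, an amine or a carboxylic acid on the core of compound 2. They also leave open how trifluoromethyl would behave on the other carbons of this ring, since it stands at only one place among them.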